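The compounds below may be only part of what the source reports. "The series", "measured", "known", "first", "only" and "open" are said of these compounds alone.

Working notes on the series. In a functional assay on A549 cells (Homo sapiens) for antiproliferative activity, read by MTT assay, with a stated time of 48 h (on this read-out higher numbers stand for weaker inhibition and lower numbers for stronger inhibition), compound 1 `Cn1cc(-c2cnc3ccc(NS(=O)(=O)c4ccc(C(F)(F)F)cc4)nc3c2)cn1` is reported only as a limit, > 50000 nM. Compound 2 `CC(=O)Nc1nccc2ncc(-c3cnn(C)c3)cc12` also has no number, only the limit > 50000 nM. For the measured compounds named here, the data so far therefore offer only (the limit of > 50000 nM in this assay, at which 2 of the 2 values shown sit), and no measured step is available for calibration.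

Compound 3 `Cn1cc(-c2cnc3ccnc(NS(=O)(=O)c4cccs4)c3c2)cn1` changes compound 2 at one place: (thiophen-2-yl)sulfonyl in place of acetyl on a nitrogen on an aromatic ring. This puts (thiophen-2-yl)sulfonyl in place of acetyl on a nitrogen on an aromatic ring.

Compound 1 also carries a sulfonyl group on a nitrogen, yet its result in this assay remains the limit > 50000 nM, so no large gain is expected. The expected change, an at least 1.1-fold lower number from compound 2 to compound 3 (0.04 log units; that floor lies within the scatter), is small and, if it can be seen at all, towards stronger inhibition. The estimate for compound 3 is 45000 nM, with an expected range of 15000 nM to 50000 nM.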

Compound 3, half-maximal inhibitory concentration: 9400 nM
Beside the measured number, compound 3's estimate is 4.8-fold (0.68 log units) above it, outside the stated range (below it).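

In this assay, for the compounds shown here, the nitrogen on an aromatic ring is the first place where a change yields a measured number: (thiophen-2-yl)sulfonyl in place of acetyl gives an at least 5.3-fold lower number from compound 2 to compound 3 (0.72 log units; beyond the scatter). The group on this nitrogen therefore affects the read-out on the shared core, and the larger entering group, with its five-membered aromatic ring, brings stronger inhibition rather than a loss. The true size of the step remains unknown, because compound 2 is reported only as a limit: the limit of > 50000 nM in this assay, at which 2 of the 3 values shown sit.

From the compounds shown here alone, whether the gain comes from the sulfonyl or from the thiophene ring remains open, and a methylsulfonyl or phenylsulfonyl group on this nitrogen would separate the two. Also open, going by these compounds, is how a simple alkyl amine at this place would read out.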